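Swapping tert-Butyl for Cyclopropyl on a Triazole Ring

The source may hold more compounds than are shown below. What is called first, only, known or untested is meant among the compounds shown, and "the series" means these compounds.

Compound 1 `CC(C)(C)c1cn(C[C@H](O)[C@H]2OC(=O)C(OCc3ccccc3)=C2OCc2ccccc2)nn1` carries a tert-butyl group on its triazole ring. In a functional assay on A549 cells (Homo sapiens) for antiproliferative activity, read by MTT assay, with a stated time of 72 h (on this read-out higher numbers stand for weaker inhibition and lower numbers for stronger inhibition), compound 1 gives 34000 nM. Within the data shown here, that is the only actual number among the three measured compounds; the other two stop at a limit of the assay. Compound 2 `O=C1O/C(=C\Cn2cc(-c3cc(F)cc(F)c3)nn2)C(OCc2ccccc2)=C1OCc1ccccc1` uses a different linker to the shared core and bears a 3,5-difluorophenyl group on the triazole. In this assay compound 2 reaches only the limit, > 100000 nM. Compound 3 `O=C1O/C(=C\Cn2cc(-c3ccc(Br)cc3)nn2)C(OCc2ccccc2)=C1OCc1ccccc1` keeps that linker and carries 4-bromophenyl instead. In this assay compound 3 also ends at the limit, > 100000 nM. Among the measured compounds shown here, the one recorded step, a step that the two limits leave unreadable from compound 2 to compound 3, therefore gives no size, because both values sit at the limit of > 100000 nM in this assay, at which 2 of the 3 values shown sit.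

Compound 4 `O=C1O[C@H]([C@@H](O)Cn2cc(C3CC3)nn2)C(OCc2ccccc2)=C1OCc1ccccc1` keeps the core and linker of compound 1 and changes a single group: cyclopropyl in place of tert-butyl on an aromatic carbon. For the measured compounds named here, no measured step touches this change; the single recorded step concerns another position on a different linker and is unreadable. Going by the values given here, the only anchor is where compound 1 stands. The step expected in this assay is no change at the digits printed from compound 1 to compound 4 (within the scatter), meaning nothing beyond the usual scatter. Compound 4 is accordingly estimated at 34000 nM, with a likely range from 12000 nM to 100000 nM.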

Compound 4, half-maximal inhibitory concentration: 43900 nM
Compound 4: the middle estimate sits 1.3-fold (0.11 log units) below what was measured; the range from low to high includes it.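

In this assay, among these compounds, the swap at this position gives a 1.3-fold higher number from compound 1 to compound 4 (0.11 log units; within the scatter), the first readable step and the first to test a change on the triazole while the core and linker stay fixed. On this aromatic carbon of the triazole, this read-out does not tell tert-butyl from cyclopropyl, even though one has no ring and 4 heavy atoms, while the other has a three-membered ring and 3 heavy atoms. Nothing measured here gives a reason for this result.

On these data alone, whether an amine, a carboxylic acid or a longer chain on this same carbon would move the number beyond the scatter stays open, as neither compound 1 nor compound 4 shows how far this position can be changed before the read-out responds. The aryl groups on the triazole offer no guide, since they sit on a different linker and the step from compound 2 to compound 3 cannot be read because both compounds stop at a limit: the limit of > 100000 nM in this assay, at which 2 of the 4 values shown sit.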